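The compounds below may be only part of what the source reports. "The series", "measured", "known", "first", "only" and "open" are said of these compounds alone.

Measured compounds:
compound 1 `O=C(Nc1ccccc1)c1ccc(/N=N\c2c[nH]c3ccccc23)cc1` — "not active" (no number reported)
compound 2 `Cc1ccc(C)c(NC(=O)c2ccc(/N=N\c3c[nH]c4ccccc34)cc2)c1` — "not active" (no number reported)
compound 3 `O=C(Nc1cccc(Cl)c1)c1ccc(/N=N\c2c[nH]c3ccccc23)cc1` — 267000 nM

Of the compounds shown here, three sharing one core have been tested in a functional assay on P388 cells (Mus musculus) for inhibition, read by MTT assay, with a stated time of 72 h; a lower number here means a stronger inhibitor, a higher number a weaker inhibitor. Compound 1 gives "not active" (no number reported), and compound 2 likewise gives "not active" (no number reported), neither with a number attached. Compound 3 is the only one of the three with a reported figure, 267000 nM, which places it alone among the numbers shown; the other two entries carry no value to set beside it, so nothing can be said about how far compound 3 stands from them.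

Compound 4 `Cc1cccc(NC(=O)c2ccc(/N=N\c3c[nH]c4ccccc34)cc2)c1` is the next compound to be measured. It differs from compound 3 in one place: methyl in place of chloro on an aromatic carbon. Within the data shown here, no step between two measured compounds is available to guide this change. Since compound 3 gives 267000 nM and compound 1 and compound 2 give no number at all, the expectation is that compound 4 stays in the same weak region, with a step of a 1.1-fold higher number from compound 3 to compound 4 (0.05 log units; within the scatter) that is not expected to go beyond the usual scatter in either direction. Compound 4 is therefore estimated at 300000 nM, in a range from 100000 nM to 1000000 nM, with a fair chance that only a limit is reported.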

Compound 4, half-maximal inhibitory concentration: 300 nM
Compound 4: the middle estimate sits 1000-fold (3.00 log units) above what was measured; the measured number lies below the stated range.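

In this assay, the exchange of chloro for methyl on this aromatic carbon gives an 890-fold lower number from compound 3 to compound 4 (2.95 log units; beyond the scatter), although one heavy atom simply replaces another and the counts of hydrogen-bond donors, hydrogen-bond acceptors and net charge stay the same. Among these compounds, compound 1, which carries neither group on that ring, gives "not active" (no number reported), so the earlier entries offered a single weak number and gave no sign that the outcome could turn so sharply on the one group at this place. Nothing available explains why the methyl and the chloro part so widely here.

The compounds shown leave open whether the result belongs to methyl alone or extends to other groups on the same carbon, such as an ethyl, a methoxy, an amine or a trifluoromethyl. They also leave open whether a methyl on another carbon of that ring would give a number like that of compound 4, and whether a fluoro or a bromo would stay with the chloro of compound 3.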